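Halogen swap on the shared core: compound 1 to compound 3

The source may hold more compounds than are shown below. What is called first, only, known or untested is meant among the compounds shown, and "the series" means these compounds.

Among the measured compounds shown here, compound 1 `C/C(=N/NC(=O)Nc1nc(-c2ccc(F)cc2)cc(-c2ccc([N+](=O)[O-])cc2)n1)c1ccc(C)cc1` stands at the higher end of the two numbers so far. In a functional assay on the whole organism (strain Albino) with Mus musculus as the target, with a stated time of 4 h (on this read-out higher numbers stand for an effect only at larger amounts of compound and lower numbers for an effect already at smaller amounts), compound 1 gives 300 mg/kg, and compound 2 `COc1ccc(-c2cc(-c3ccc(F)cc3)nc(NC(=O)N/N=C(/C)c3ccc(C)cc3)n2)cc1` gives 100 mg/kg, a change of a 3.0-fold lower number from compound 1 to compound 2 (0.48 log units; beyond the scatter) for methoxy in place of nitro on an aromatic carbon. Compound 3 `C/C(=N/NC(=O)Nc1nc(-c2ccc(Cl)cc2)cc(-c2ccc([N+](=O)[O-])cc2)n1)c1ccc(C)cc1` is the next member; it differs from compound 1 by chloro in place of fluoro on an aromatic carbon. For the measured compounds named here, no measured step touches the halogen side of the core: the single step from compound 1 to compound 2 concerns the nitro-bearing ring and says nothing about chloro against fluoro. Going by the values given here, with no directly comparable step available, the expectation for this assay is no change beyond the scatter, that is an expected step of no change at the digits printed from compound 1 to compound 3 (within the scatter). Compound 3 is therefore estimated at 300 mg/kg, with a range from 150 mg/kg to 600 mg/kg.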

Compound 3, dose for half-maximal effect: 300 mg/kg
The estimate for compound 3 equals the measured number at the digits printed; measured number inside the range.
By their numbers in this assay, from the lowest: compound 2; then compounds 1 and 3 (each within the scatter of the next).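

In this assay, among the compounds shown here, chloro in place of fluoro, on the aromatic carbon para to a large group, gives no change at the digits printed from compound 1 to compound 3 (within the scatter), the first reading at this position of the series. For the compounds shown here, with the nitro-bearing ring held constant, the 4-fluorophenyl to 4-chlorophenyl change leaves the read-out within the scatter, whereas the only earlier step, a 3.0-fold lower number from compound 1 to compound 2 (0.48 log units; beyond the scatter), lay on the nitro-bearing ring and went beyond it. Nothing available bears on why the two halogens read alike.

Going by these compounds, whether chloro for fluoro reads the same with the methoxy group of compound 2 in place of nitro stays open. Also open, on these data alone, is how an amine, a carboxylic acid or a longer chain would read at this same position in place of the halogen.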